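Fluorobenzyl position change carried across two cores

The source may report more compounds than this note shows. Statements on the series, on what has been measured and on what is new or still open speak of the compounds shown alone.

Measured so far, in an assay on isolated protein for inhibition of protein deacetylase HDAC6 (Homo sapiens), read by fluorescence, with a stated time of 1 h, tested at 100 nM; a lower number here means less inhibition, a higher number more inhibition at the concentration tested (going by the name of the read-out):
Compound 1, `O=C(/C=C/c1ccc(OCc2nc(C3CCN(Cc4ccccc4F)CC3)no2)cc1)NO`, gives 68%.
Compound 2, `O=C(/C=C/c1ccc(OCc2nc(C3CCN(Cc4ccc(F)cc4)CC3)no2)cc1)NO`, gives 75%.
Compound 3, `CN(Cc1nc(C2CCN(Cc3ccccc3F)CC2)no1)c1ncc(C(=O)NO)cn1`, gives 44%.

Compound 1 and compound 2 share one core and differ by 4-fluorophenyl in place of 2-fluorophenyl on a saturated chain carbon bound to an amine nitrogen in a ring. That change reads as a number 7 percentage points higher from compound 1 to compound 2 (within the scatter), so the two numbers are not told apart by this measurement. Compound 3 is built on a different core; the difference between the two cores is not broken down here. Compound 3 gives the lowest of the three numbers in this assay, and its distance to compound 1 and to compound 2 is beyond the usual scatter.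

Compound 4, `CN(Cc1nc(C2CCN(Cc3ccc(F)cc3)CC2)no1)c1ncc(C(=O)NO)cn1`, is not yet measured. It stands to compound 3 as compound 2 stands to compound 1: 4-fluorophenyl in place of 2-fluorophenyl on a saturated chain carbon bound to an amine nitrogen in a ring, the same change in the same place. For the measured compounds named here, the one measured example of this change gives a number 7 percentage points higher from compound 1 to compound 2 (within the scatter), so only a small step is expected in this assay, about a number 6 percentage points higher from compound 3 to compound 4 (within the scatter). On that basis compound 4 is estimated at 50%, likely between 38% and 62%. Going by the values given here, a single measured pair is a thin basis, and the core of compound 3 has no second example of its own.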

Compound 4, a percentage reported as inhibition, at one concentration (the size of the read-out at that concentration, not a potency): 65%
Compound 4: the middle estimate sits 15 percentage points below what was measured; measured number above the stated range.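

On the core of compound 3, 4-fluorophenyl in place of 2-fluorophenyl reads in this assay as a number 21 percentage points higher from compound 3 to compound 4 (beyond the scatter). Set beside the step on the first core, the size of the change does not separate the two cores: the same change on two cores in this assay, a number 7 percentage points higher (within the scatter) from compound 1 to compound 2 and a number 21 percentage points higher (beyond the scatter) from compound 3 to compound 4, 14 percentage points apart, within the scatter of two such steps. The change can therefore be carried to a second core without a step that can be told apart from the first, but two pairs do not show that its size is the same on both cores, nor that it depends on the core.

Open, as far as these compounds go, is whether the same reading holds for other groups at this place, such as a plain benzyl without fluorine or a simple methyl on the ring amine nitrogen, and whether it survives a carboxylic acid in place of the hydroxamic acid. From the compounds shown here alone, all of these numbers are inhibition at a single concentration, so the size of the change as a difference in potency also remains open.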